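The compounds below may be only part of what the source reports. "The series", "measured", "known", "first", "only" and "open" are said of these compounds alone.

Compound 1 `O=C(CCSC(=S)NCc1cccnc1)NCc1ccccc1` does not give a number: in a functional assay on Bel-7402 cells (Homo sapiens) for cytotoxicity, read by resazurin assay, with a stated time of 72 h (a lower number here means a stronger inhibitor, a higher number a weaker inhibitor), compound 1 gives > 100000 nM, which is a limit of the assay, namely (the limit of > 100000 nM in this assay, at which 1 of the 2 values shown sits). For the measured compounds named here, compound 2 `S=C(NCc1cccnc1)SCCc1nnc(-c2ccccc2)o1` holds the only numerical value shown; in this assay compound 2 gives 1230 nM. Compound 3 `S=C(NCc1cccnc1)SCCc1nnc(-c2cc3ccccc3s2)o1` differs from compound 2 by 1-benzothiophen-2-yl in place of phenyl on an aromatic carbon. Going by the values given here, no measured step covers this change, so the expectation rests on compound 2 alone. The expected step is a 1.5-fold lower number from compound 2 to compound 3 (0.19 log units; within the scatter), small and within the usual scatter, toward a stronger inhibitor if anything. Compound 3 is estimated at 800 nM, with a range from 250 nM to 3000 nM.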

Compound 3, half-maximal inhibitory concentration: 6890 nM
Compound 3: the middle estimate sits 8.6-fold (0.94 log units) below what was measured, outside the stated range (above it).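

In this assay, the aromatic carbon of the five-membered ring does not treat these two aromatic groups alike: 1-benzothiophen-2-yl in place of phenyl gives a 5.6-fold higher number from compound 2 to compound 3 (0.75 log units; beyond the scatter). The larger fused group is therefore not a gain at this position, and the direction of the step is now measured for this single pair. Nothing shown accounts for the step. Still open, going by these compounds, is how a thiophene, a pyridine, a methoxy-bearing phenyl or a plain methyl would read on this carbon.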